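Methyl in place of chloro: working notes on four compounds

The source may report more compounds than this note shows. Statements on the series, on what has been measured and on what is new or still open speak of the compounds shown alone.

Measured compounds:
compound 1, `Cc1ccc(NC(C(=O)CCc2ccncc2)c2ccc(Cl)cc2)c(Cl)c1`: > 10000 nM
compound 2, `Cc1ccc(C(Nc2ccc(C)cc2Cl)C(=O)CCc2ccncc2)cc1`: > 10000 nM
compound 3, `Cc1ccccc1C(Nc1ccc(Cl)cc1C(F)(F)F)C(=O)CCc1ccncc1`: 469 nM

In an assay on isolated protein for binding affinity to corticotropin-releasing factor receptor 1 (Homo sapiens) (on this read-out lower numbers stand for stronger inhibition and higher numbers for weaker inhibition), compound 1 gives > 10000 nM, a limit of the assay and not a number. Compound 2 gives > 10000 nM, again a limit and not a number. Among the compounds with values here, compound 3 gives 469 nM, the only number among the three. Compound 1 and compound 2 differ by methyl in place of chloro on an aromatic carbon. This gives a step that the two limits leave unreadable from compound 1 to compound 2, which cannot be read because the limit of > 10000 nM in this assay, at which 2 of the 3 values shown sit, covers both ends. The difference between the core of compound 1 and the core of compound 3 is not broken down here.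

Compound 4, `Cc1ccc(NC(C(=O)CCc2ccncc2)c2ccccc2C)c(C(F)(F)F)c1`, is not yet measured. It differs from compound 3 by methyl in place of chloro on an aromatic carbon. This is the same kind of change as that between compound 1 and compound 2 but not the same: in compound 4 the place is meta to a trifluoromethyl group and para to a large group, whereas in compound 2 the place is para to a large group only. The measured step gives no reading of size, so the expectation rests on compound 3 alone, which gives 469 nM. For compound 4 the expected step is a 1.3-fold higher number from compound 3 to compound 4 (0.11 log units; within the scatter), close to no change within the usual scatter. Compound 4 is therefore estimated at 600 nM in this assay, between 150 nM and 2500 nM.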

Compound 4, inhibition constant: 641 nM
Beside the measured number, compound 4's estimate is 1.1-fold (0.03 log units) below it, and the stated range covers the measured number.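

In this assay, methyl in place of chloro on an aromatic carbon, meta to a trifluoromethyl group, gives a 1.4-fold higher number from compound 3 to compound 4 (0.14 log units; within the scatter), so on this core the two compounds cannot be told apart. Within the data shown here, this is the only step of this kind that can be read, as the matching step on the core of compound 1 cannot be read because both of its ends rest on a limit and not on a number: the limit of > 10000 nM in this assay, at which 2 of the 4 values shown sit. The series therefore gives one reading on one core, and it does not show that the change carries over to another core, nor does it show how the change would read on the core of compound 1 if both ends there gave numbers.

Open, on these data alone, is how the same change would read on a further core with a measurable value at both ends. Also open, as far as these compounds go, is what a group other than methyl or chloro would give at this place, such as a nitrile or an amine.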